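Trifluoromethyl Added to a Hydroxamic Acid Ring

A few compounds are considered here, and "the series" means these few. Any claim that something is new, unique, unknown or untested is made for them only; others in the source may bear on it.

Compound 1, `O=C(CCCCCCC(=O)c1ccccc1)NO`: 500 nM in an assay on isolated protein for inhibition of histone deacetylase 8 (Homo sapiens); a higher number here means a weaker inhibitor, a lower number a stronger inhibitor
Compound 2, `O=C(CCCCCCCC(=O)c1ccccc1)NO`: 65 nM in this assay

Of these two, compound 2 gives the lower number in this assay. Within the data shown here, the one known step, a 7.7-fold lower number from compound 1 to compound 2 (0.89 log units; beyond the scatter), lengthens the saturated chain between the hydroxamic acid and the aryl ketone by one carbon and nothing else. Compound 3, `O=C(CCCCCCCC(=O)c1ccc(C(F)(F)F)cc1)NO`, keeps that longer chain and differs from compound 2 in a single place: trifluoromethyl in place of hydrogen on an aromatic carbon. Among the measured compounds shown here, no measured step touches the aromatic ring; the step from compound 1 to compound 2 concerns the chain alone, so it says nothing about how a new group on the ring would be tolerated. With no bearing evidence, the expected step of a 1.1-fold lower number from compound 2 to compound 3 (0.03 log units; within the scatter) in this assay is none beyond the scatter, held with wide uncertainty. Compound 3 is therefore estimated at 60 nM, within a range from 20 nM to 200 nM.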

Compound 3, half-maximal inhibitory concentration: 45 nM
Beside the measured number, compound 3's estimate is 1.3-fold (0.12 log units) above it, within the range that was stated.
By their numbers in this assay, from the lowest: compounds 3 and 2 (each within the scatter of the next); then compound 1.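

In this assay, trifluoromethyl in place of hydrogen on an aromatic carbon, para to a large group, gives a 1.4-fold lower number from compound 2 to compound 3 (0.16 log units; within the scatter). Among these compounds, this is the first reading at the ring, and it shows that this carbon can carry a group of 4 heavy atoms with no difference that the assay can separate from scatter, unlike the chain change, which gives a 7.7-fold lower number from compound 1 to compound 2 (0.89 log units; beyond the scatter). Nothing available explains why the ring accepts this group.

Still open, on these data alone, is whether this carbon would accept other groups as readily, such as an amine, a carboxylic acid or a methoxy group. Also open, as far as these compounds go, is whether trifluoromethyl would give a similar result on another carbon of the ring, or on a compound with a longer chain.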